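The compounds below may be only part of what the source reports. "The series", "measured", "known", "first", "only" and "open" are said of these compounds alone.

Compound 1 `N#Cc1cc(NCc2ccccc2[N+](=O)[O-])c2cn[nH]c2c1`: > 100000 nM
Compound 2 `O=[N+]([O-])c1ccccc1CNc1cc(Br)cc2[nH]ncc12`: 39000 nM

In an assay for inhibition of Tryptophan 2,3-dioxygenase (Homo sapiens), with stated times of 10 min and 60 min (on this read-out higher numbers stand for weaker inhibition and lower numbers for stronger inhibition), compound 1 gives only a limit, > 100000 nM. Going by the values given here, compound 2 gives 39000 nM, the one number measured so far. Among the compounds with values here, the sole measured step is an at least 2.5-fold lower number from compound 1 to compound 2 (0.40 log units; beyond the scatter). Compound 3 `O=[N+]([O-])c1ccc(O)cc1CNc1cc(Br)cc2[nH]ncc12` differs from compound 2 by hydroxy in place of hydrogen on an aromatic carbon. Within the data shown here, no measured step bears on this change, as the one step seen concerns bromo in place of cyano, so no step beyond the scatter is expected in this assay. Compound 3 is therefore estimated at 39000 nM, between 15000 nM and 100000 nM. For compound 3 the expected step is no change at the digits printed from compound 2 to compound 3 (within the scatter).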

Compound 3, half-maximal inhibitory concentration: 460 nM
Compound 3: the middle estimate sits 85-fold (1.93 log units) above what was measured; measured number below the stated range.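

Hydroxy on the aromatic carbon para to a nitro group gives an 85-fold lower number from compound 2 to compound 3 (1.93 log units; beyond the scatter) in this assay, which shows that this position, unchanged in the earlier compounds, responds strongly to the addition of one oxygen atom. The earlier pair spoke only to bromo in place of cyano. Nothing measured here accounts for the size of this step.

On these data alone, whether a methoxy group, an amine or fluorine at this position would match hydroxy remains open. So does whether the step would persist with nitrile in place of bromo, or with a carboxylic acid in place of the nitro group.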